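The source may report more compounds than this note shows. Statements on the series, on what has been measured and on what is new or still open speak of the compounds shown alone.

Compound 1 `CCCS(=O)(=O)c1cccc(C#Cc2cc(Cl)ccc2OCC(=O)O)c1`: 11 mL.min-1.g-1
Compound 2 `COCCNS(=O)(=O)c1ccc(C)c(C#Cc2cc(Cl)ccc2OCC(=O)O)c1`: < 10 mL.min-1.g-1, a limit
Compound 3 `Cc1ccc(S(=O)(=O)NC(C)C)cc1C#Cc1cc(Cl)ccc1OCC(=O)O`: < 10 mL.min-1.g-1, a limit

These values come from an in vitro ADME assay on microsomes from liver (Homo sapiens) for metabolic stability, read by LC-MS, tested at 1 uM; a higher number here means faster removal of the compound, a lower number slower removal. Compound 3 stands at the limit of < 10 mL.min-1.g-1 in this assay, at which 2 of the 3 values shown sit, so it has a limit and not a number. Compound 4 `Cc1ccc(S(=O)(=O)N2CCCCC2C)cc1C#Cc1cc(Cl)ccc1OCC(=O)O` carries 2-methylpiperidin-1-yl in place of isopropylamino on a sulfonyl sulfur. For the measured compounds named here, the one measured step bearing on this place is a step that the two limits leave unreadable from compound 2 to compound 3, so it offers no size to carry over. Going by the values given here, the only number in the set is that of compound 1, at 11 mL.min-1.g-1, which gives a loose guide. A modest rise is therefore expected, an at least 1.4-fold higher number from compound 3 to compound 4 (0.14 log units; that floor lies within the scatter). The estimate for compound 4 is 14 mL.min-1.g-1, with an expected range of 7 mL.min-1.g-1 to 30 mL.min-1.g-1.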

Compound 4, intrinsic clearance in microsomes: 89 mL.min-1.g-1
Estimate against measurement, compound 4: 6.4-fold (0.80 log units) below; the whole stated range lies below it.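

In this assay, the sulfonyl sulfur proves to be a place where the amine matters: 2-methylpiperidin-1-yl in place of isopropylamino gives an at least 8.9-fold higher number from compound 3 to compound 4 (0.94 log units; beyond the scatter). In place of (2-methoxyethyl)amino, the same group gives an at least 8.9-fold higher number from compound 2 to compound 4 (0.94 log units; beyond the scatter). Both sizes are floors, because each step starts from a limit: the limit of < 10 mL.min-1.g-1 in this assay, at which 2 of the 4 values shown sit.

The compounds shown do not separate the part played by the ring from that of its methyl group. As far as these compounds go, it also remains open how piperidin-1-yl without the methyl, or morpholin-4-yl, would stand on the same sulfonyl sulfur.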